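Chloro to methyl: estimating growth inhibition

The source may report more compounds than this note shows. Statements on the series, on what has been measured and on what is new or still open speak of the compounds shown alone.

For the measured compounds named here, in a functional assay on OVCAR-3 cells (Homo sapiens) for antiproliferative activity (a higher number here means a weaker inhibitor of growth, a lower number a stronger inhibitor of growth), compound 2 (`Cc1cc(C)c2c(O)cc(-c3cccc(Cl)c3)nc2n1`) gives 170 nM, the higher of the two numbers so far and thus the weaker growth inhibitor, while compound 1 (`Cc1cc(C)c2c(O)cc(-c3cccc(F)c3)nc2n1`) gives 18.2 nM. Compound 3 (`Cc1cccc(-c2cc(O)c3c(C)cc(C)nc3n2)c1`) differs from compound 2 by methyl in place of chloro on an aromatic carbon. Going by the values given here, the only measured step, a 9.3-fold higher number from compound 1 to compound 2 (0.97 log units; beyond the scatter), swapped fluoro for chloro and was modest but beyond the scatter. Among the compounds with values here, no measured step involves methyl, so no change beyond the scatter is expected. The estimated step is a 1.3-fold lower number from compound 2 to compound 3 (0.12 log units; within the scatter). For compound 3 the expected value is 130 nM, with a range of 35 nM to 480 nM.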

Compound 3, concentration for 50% growth inhibition: 30200 nM
Compound 3: middle estimate off by 230-fold (2.37 log units), on the low side; the whole stated range lies below it.
By their numbers in this assay, from the lowest: compound 1; then compound 2; then compound 3.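

In this assay, this position on the ring proves far more sensitive than the earlier swap of fluoro for chloro showed: methyl in place of chloro gives a 180-fold higher number from compound 2 to compound 3 (2.25 log units; beyond the scatter), and methyl in place of fluoro gives a 1700-fold higher number from compound 1 to compound 3 (3.22 log units; beyond the scatter). Chloro and methyl each count as one heavy atom with no hydrogen-bond donors or acceptors, so those counts do not separate them, yet the step is large. No measurement available here accounts for this step. Still open, going by these compounds, is how a hydroxyl, a methoxy or an amine at this carbon would compare. Also open, on these data alone, is whether methyl in place of chloro has as large an effect elsewhere on the shared core.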